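The source may report more compounds than this note shows. Statements on the series, on what has been measured and on what is new or still open speak of the compounds shown alone.

In an ADME assay on MT4 cells (Homo sapiens) for cytotoxicity, read by MTT assay, with a stated time of 5 days (on this read-out higher numbers stand for lower toxicity in this test and lower numbers for higher toxicity in this test), compound 2 `CC(C)CN(c1ccnc(Nc2ccc(C#N)cc2)n1)c1c(F)cc(-c2ccc(C#N)cc2)cc1F` gives 241000 nM, the highest of the two numbers in hand, and its nearest neighbour is compound 1 `CN(c1ccnc(Nc2ccc(C#N)cc2)n1)c1c(F)cc(-c2ccc(C#N)cc2)cc1F`, which in this assay gives 148000 nM; the two lie within the scatter of each other. Compound 3 `N#Cc1ccc(Nc2nccc(N(CC(O)CO)c3c(F)cc(-c4ccc(C#N)cc4)cc3F)n2)cc1` has not yet been measured in this assay. It differs from compound 2 in one place: 1,2-dihydroxyethyl in place of isopropyl on a saturated chain carbon bound to a nitrogen on an aromatic ring. Among the compounds with values here, the only measured step that bears on this position is a 1.6-fold higher number from compound 1 to compound 2 (0.21 log units; within the scatter), which shows that changing the group on this saturated chain carbon did not move the number beyond the scatter. With nothing further to go on, the expected step is a 1.0-fold higher number from compound 2 to compound 3 (0.02 log units; within the scatter), that is, none beyond the scatter. On that basis compound 3 is estimated to give about 250000 nM in this assay, with a range from 120000 nM to 520000 nM.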

Compound 3, half-maximal cytotoxic concentration: 19500 nM
Estimate against measurement, compound 3: 13-fold (1.11 log units) above; the whole stated range lies above it.
By their numbers in this assay, from the lowest: compound 3; then compounds 1 and 2 (each within the scatter of the next).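

In this assay, the group on this saturated chain carbon does matter: 1,2-dihydroxyethyl in place of isopropyl gives a 12-fold lower number from compound 2 to compound 3 (1.09 log units; beyond the scatter), and in place of hydrogen it gives a 7.6-fold lower number from compound 1 to compound 3 (0.88 log units; beyond the scatter). The position therefore responds to the group placed there, which a 1.6-fold higher number from compound 1 to compound 2 (0.21 log units; within the scatter) alone did not reveal, and both new steps point towards higher toxicity in this test. Nothing available explains why the 1,2-dihydroxyethyl group shifts the number when isopropyl does not.

The compounds shown leave open whether this shift is specific to 1,2-dihydroxyethyl or would also appear with a hydroxymethyl group, an amine or a carboxylic acid at this place. They also leave open how a longer chain carrying no oxygen would behave.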